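A few compounds are considered here, and "the series" means these few. Any claim that something is new, unique, unknown or untested is made for them only; others in the source may bear on it.

Measured so far:
compound 1 `CCCCCCCCCCCC(=O)OC[C@H](CSC[C@@H](N)C(=O)N[C@@H](C)CO)OC(=O)CCCCCCCCCCC` – 1560 nM
compound 2 `CCCCCCCCCCCC(=O)OC[C@H](CSC[C@@H](N)C(=O)NC(C)CCC(C)C)OC(=O)CCCCCCCCCCC` – 190 nM
compound 3 `CCCCCCCCCCCC(=O)OC[C@H](CSC[C@@H](N)C(=O)NCCCCCCCCCC(=O)O)OC(=O)CCCCCCCCCCC` – 4400 nM

All three were run in an assay on HEK293 cells for agonist activity at Toll-like receptor 2 (Homo sapiens); a lower number here means that less compound is needed, a higher number that more compound is needed for the effect. Compound 1 holds the second highest number of the three: the step of a 2.8-fold higher number from compound 1 to compound 3 (0.45 log units; beyond the scatter) and the step of an 8.2-fold lower number from compound 1 to compound 2 (0.91 log units; beyond the scatter) bracket it, both beyond the scatter and both made on the same amide-type nitrogen.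

Compound 4 `CCCCCCCCCCCC(=O)OC[C@H](CSC[C@@H](N)C(=O)NCCN)OC(=O)CCCCCCCCCCC` is compound 1 with 2-aminoethyl in place of 1-(hydroxymethyl)ethyl on an amide-type nitrogen. For the measured compounds named here, no measured step shares this exact change; the two steps on that nitrogen went in opposite directions, so they set no direction for 2-aminoethyl. In this assay the step is therefore expected to stay near the scatter, a 1.0-fold higher number from compound 1 to compound 4 (0.01 log units; within the scatter), and compound 4 is estimated at 1600 nM, within 500 nM to 5000 nM.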

Compound 4, half-maximal effective concentration: 5240 nM
For compound 4 the middle estimate is 3.3-fold (0.52 log units) below the measured one; the whole stated range lies below it.
By their numbers in this assay, from the lowest: compound 2; then compound 1; then compounds 3 and 4 (each within the scatter of the next).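

On the amide-type nitrogen, 2-aminoethyl moves the number up, with a 3.4-fold higher number from compound 1 to compound 4 (0.53 log units; beyond the scatter), and it lands level with 9-carboxynonyl, with a 1.2-fold higher number from compound 3 to compound 4 (0.08 log units; within the scatter). So a short amine-ended group and a long acid-ended group give the same read-out here, while 1,4-dimethylpentyl, which carries neither an amine nor a carboxylic acid, stays far lower, with a 28-fold higher number from compound 2 to compound 4 (1.44 log units; beyond the scatter). Nothing available explains these differences.

The compounds shown leave open whether a longer chain ending in an amine would stay level with compound 4. They also leave open whether an unbranched alkyl chain would match compound 2.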